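Series notes: assay limits and the outlook for compound 4

A few compounds are considered here, and "the series" means these few. Any claim that something is new, unique, unknown or untested is made for them only; others in the source may bear on it.

Compound 1 `N#CC1=C(N)Oc2c(c3nc4ccccc4nc3c3ccccc23)C12C(=O)N(Cc1cnnn1-c1ccc(F)cc1)c1ccccc12` is the 4-fluorophenyl member of the series. In an ADME assay on HUVEC cells (Homo sapiens) for antiproliferative activity, read by MTT assay, with a stated time of 48 h (on this read-out lower numbers stand for stronger inhibition and higher numbers for weaker inhibition), compound 1 gives only a limit, > 50000 nM. Compound 2 `Cc1ccc(-n2nncc2CN2C(=O)C3(C(C#N)=C(N)Oc4c3c3nc5ccccc5nc3c3ccccc43)c3ccccc32)c(C)c1` carries 2,4-dimethylphenyl in place of 4-fluorophenyl on an aromatic nitrogen; in this assay compound 2 likewise gives only a limit, > 50000 nM. The step that the two limits leave unreadable from compound 1 to compound 2 therefore cannot be read. Compound 3 `CCOc1ccc(-n2nncc2CN2C(=O)C3(C(C#N)=C(N)Oc4c(N)cc5nc6ccccc6nc5c43)c3ccccc32)cc1` is also known in this assay only by a limit, > 50000 nM. Every value shown sits at the limit of > 50000 nM in this assay, at which 3 of the 3 values shown sit, and compound 3 stands at that limit with the others. Compound 4 `COc1ccc(OC)c(-n2nncc2CN2C(=O)C3(C(C#N)=C(N)Oc4c(N)cc5nc6ccccc6nc5c43)c3ccccc32)c1` differs from compound 3 by 2,5-dimethoxyphenyl in place of 4-ethoxyphenyl on an aromatic nitrogen. For the measured compounds named here, no measured step reads a change at this position, and all measured values are limits, so for compound 4 in this assay no step beyond the scatter is expected, a step that the limit leaves unreadable from compound 3 to compound 4. Compound 4 is estimated at 60000 nM, within 20000 nM to 200000 nM, most probably reported again only as a limit.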

Compound 4, half-maximal inhibitory concentration: > 50000 nM
Compound 4: no number, only a limit (the forecaster's own chance of this, stated with the estimate: 85%); the middle value is on the limit's open side.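

No step from compound 3 to compound 4 can be read in this assay: the limit of > 50000 nM in this assay, at which 4 of the 4 values shown sit.

The compounds shown leave open whether the group on the aromatic nitrogen changes the read-out at all in this assay.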